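A few compounds are considered here, and "the series" means these few. Any claim that something is new, unique, unknown or untested is made for them only; others in the source may bear on it.

Compound 1 `O=C(Nc1ccc(-n2ccc3nc(C(=O)NCc4ccccc4)ccc32)cc1)Nc1ccc(Cl)c(C(F)(F)F)c1`: in a functional assay on A375P cells (Homo sapiens) for cytotoxicity, read by MTT assay (on this read-out lower numbers stand for stronger inhibition and higher numbers for weaker inhibition), compound 1 gives 1100 nM.
Compound 2 `COC(=O)c1ccc2c(ccn2-c2cccc(NC(=O)c3cccc(C(F)(F)F)c3)c2)n1`: compound 2 gives only a limit, > 10000 nM.
Compound 3 `O=C(Nc1ccc(-n2ccc3nc(C(=O)NCc4ccccc4)ccc32)cc1)Nc1cccc(Cl)c1Cl`: compound 3 gives only a limit, > 10000 nM.

Among the compounds with values here, compound 1 holds the only numerical value in the set; the other two entries are limits, namely (the limit of > 10000 nM in this assay, at which 2 of the 3 values shown sit). Within the data shown here, the single measured step, an at least 9.0-fold higher number from compound 1 to compound 3 (0.95 log units; beyond the scatter), concerns the aryl group on the urea and not the carbonyl changed here. Compound 4 `COC(=O)c1ccc2c(ccn2-c2ccc(NC(=O)Nc3ccc(Cl)c(C(F)(F)F)c3)cc2)n1` differs from compound 1 by methoxy in place of benzylamino on a carbonyl carbon. Among the measured compounds shown here, no measured step covers this change directly. Compound 2, which also carries a methoxycarbonyl group though on a differently substituted linker, reaches only a limit. A loss is therefore expected for compound 4 in this assay, estimated at a 3.6-fold higher number from compound 1 to compound 4 (0.56 log units; beyond the scatter). The estimate for compound 4 is 4000 nM, with an expected range of 1000 nM to 20000 nM.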

Compound 4, half-maximal inhibitory concentration: 3600 nM
Compound 4: the middle estimate sits 1.1-fold (0.05 log units) above what was measured; measured number inside the range.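

Within the data shown here, the first direct reading at this carbonyl carbon, with methoxy in place of benzylamino, is a modest loss: a 3.3-fold higher number from compound 1 to compound 4 (0.51 log units; beyond the scatter). The benzylamino group is therefore not needed for a measurable value on this urea-bearing scaffold. Compound 4 still gives a number in this assay and does not fall to the assay limit: the limit of > 10000 nM in this assay, at which 2 of the 4 values shown sit.

The change removes the aromatic ring and the amide hydrogen together, so their shares in the step cannot be separated. A methylamino group or a hydroxyl group, which gives the carboxylic acid, on the same carbonyl carbon would bear on that question.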